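Methyl on the Oxygen: Following Compound 1 Toward Compound 3

The source may report more compounds than this note shows. Statements on the series, on what has been measured and on what is new or still open speak of the compounds shown alone.

compound 1 `CC1CN(c2ccccc2)NC(=O)N1O` — 6000 nM
compound 2 `Cc1cccc(N2CC(C)N(O)C(=O)N2)c1` — 8400 nM

In an assay on RBL-1 cells for inhibition of Polyunsaturated fatty acid 5-lipoxygenase (Rattus norvegicus) (a higher number here means a weaker inhibitor, a lower number a stronger inhibitor), compound 1 gives 6000 nM and compound 2 gives 8400 nM; the two sit close together, as a 1.4-fold higher number from compound 1 to compound 2 (0.15 log units; within the scatter) shows, so neither stands apart. Compound 3 `CON1C(=O)NN(c2ccccc2)CC1C` differs from compound 1 by methyl in place of hydrogen on an oxygen. Among the measured compounds shown here, the single measured step concerns a methyl on an aromatic carbon, not the oxygen, and so offers no direct guide for this change. Without a comparable step, a weaker number is expected for compound 3, a 6.7-fold higher number from compound 1 to compound 3 (0.82 log units; beyond the scatter), with wide uncertainty. Compound 3 is estimated at 40000 nM, in the range 6000 nM to 300000 nM.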

Compound 3, half-maximal inhibitory concentration: 22000 nM
Estimate against measurement, compound 3: 1.8-fold (0.26 log units) above, and the stated range covers the measured number.
By their numbers in this assay, from the lowest: compounds 1 and 2 (each within the scatter of the next); then compound 3.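

Of the two steps shown, only hydroxy to methoxy moves the number beyond the scatter in this assay, with a 3.7-fold higher number from compound 1 to compound 3 (0.56 log units; beyond the scatter) as a modest change. This oxygen therefore responds to a single methyl in place of hydrogen, whereas the methyl on an aromatic carbon left the number within the scatter. Nothing available explains the rise. Going by these compounds, whether an ethyl or an acetyl on this oxygen would read differently from methyl remains open. So does the effect of an amine in place of the hydroxy.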